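The source may hold more compounds than are shown below. What is called first, only, known or untested is meant among the compounds shown, and "the series" means these compounds.

Measured so far:
Compound 1, `O=C(CN(c1nc(Cl)nc2[nH]cnc12)C1CC1)N[C@@H](CO)C(=O)OCc1ccccc1`, gives 34.5% in a functional assay on the whole organism (Tail, strain ICR) with Mus musculus as the target, in the tail flick test, with a stated time of 90 min, at a dose of 25 umol/kg by the oral route; on this read-out higher numbers stand for a stronger effect at the one dose given and lower numbers for a weaker effect.
Compound 2, `O=C(O)CC[C@H](NC(=O)CN(c1nc(Cl)nc2[nH]cnc12)C1CC1)C(=O)O`, gives 44.7% in this assay.

Among the compounds with values here, of the two numbers available, compound 2 stands highest; compound 1 is its only neighbour and sits lower by a gap that lies beyond the usual scatter. Compound 3, `C[C@H](NC(=O)CN(c1nc(Cl)nc2[nH]cnc12)C1CC1)C(=O)O`, has not yet been tested in this assay. It differs from compound 2 in a single place: hydrogen in place of carboxymethyl on a saturated chain carbon, two bonds along the chain from an amide-type nitrogen and a carbonyl carbon. The group that leaves is a carboxymethyl on a saturated chain carbon, two bonds along the chain from an amide-type nitrogen and a carbonyl carbon; everything else in compound 2 is kept. Within the data shown here, no step between two measured compounds shows what such a change does in this assay, and the two measured values themselves span only a modest range. A small loss is therefore expected, roughly within the scatter, with the step estimated at a number 8.7 percentage points lower from compound 2 to compound 3 (within the scatter). For compound 3 the expected result in this assay is 36%, within a range from 15% to 58%.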

Compound 3, a percentage reported as activity, at one dose (the size of the read-out at that dose, not a potency): 43.5%
For compound 3 the middle estimate is 7.5 percentage points below the measured one; the measured number falls inside the stated range.
By their numbers in this assay, from the lowest: compounds 1, 3 and 2 (each within the scatter of the next, the first and the last beyond it).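

At this saturated chain carbon, the first step available in this assay is a number 1.2 percentage points lower from compound 2 to compound 3 (within the scatter) on going from carboxymethyl to hydrogen. The carboxymethyl can therefore be removed from this place without a difference beyond the scatter, and at the one oral dose given, this read-out does not separate compound 2 from compound 3. Nothing in the available data accounts for this result.

The compounds shown leave open whether a different group on this same carbon, such as an aminomethyl, a hydroxymethyl or a longer alkyl chain, would also leave the read-out within the scatter. They also leave open whether the second carboxylic acid of compound 2 would matter at a different dose or time.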